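Notes on the step from trifluoromethyl to methoxy

A few compounds are considered here, and "the series" means these few. Any claim that something is new, unique, unknown or untested is made for them only; others in the source may bear on it.

Measured so far in a functional assay on BaF3 cells (Mus musculus) for inhibition, read by MTT assay, with a stated time of 3 days (a lower number here means a stronger inhibitor of growth, a higher number a weaker inhibitor of growth), with these values
- compound 1 (`O=C(Nc1ccc(Br)cc1)Nc1ccc(Nc2ncnc3c2OCCN3)cc1`) with 10000 nM
- compound 2 (`O=C(Nc1ccc(Nc2ncnc3c2OCCN3)cc1)Nc1ccc(C(F)(F)F)cc1`) with 10000 nM

Going by the values given here, compound 1 and compound 2 stand level, and compound 2 sits at the same number as its only neighbour (compound 2 at 10000 nM). The next structure, compound 3 (`COc1ccc(NC(=O)Nc2ccc(Nc3ncnc4c3OCCN4)cc2)cc1`), carries methoxy in place of trifluoromethyl on an aromatic carbon. Among the compounds with values here, only one measured step bears on this: no change at the digits printed from compound 1 to compound 2 (within the scatter) (trifluoromethyl in place of bromo). Methoxy itself has no measured precedent here, so no shift beyond the scatter is expected in this assay, in either direction. The estimated step is no change at the digits printed from compound 2 to compound 3 (within the scatter) (an expectation only). Estimated for compound 3 is 10000 nM (expected range 4000 nM to 12000 nM).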

Compound 3, concentration for 50% growth inhibition: > 10000 nM
Compound 3: a limit, no number; the forecaster's own chance of this, stated with the estimate: 30%; the middle value sits exactly at the limit.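

In this assay compound 3 gives > 10000 nM, which is a limit and not a number. Methoxy, with a hydrogen-bond acceptor that trifluoromethyl lacks, gives a number no lower from compound 2 to compound 3 (the limit leaves the size open), and in place of bromo at this position it gives a number no lower from compound 1 to compound 3 (the limit leaves the size open). The size of the steps to compound 3 from compound 1 and from compound 2 cannot be read, because of a limit: the limit of > 10000 nM in this assay, at which 1 of the 3 values shown sits.

Going by these compounds, whether any group on this aromatic carbon can give a lower number stays open. An amine or a carboxylic acid here would test this.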